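Para substituent swap on the aryl thiosemicarbazone series

The source may hold more compounds than are shown below. What is called first, only, known or untested is meant among the compounds shown, and "the series" means these compounds.

Values below come from a functional assay on HL-60 cells (Homo sapiens) for antiproliferative activity, read by sulforhodamine B assay, with a stated time of 72 h (on this read-out lower numbers stand for stronger inhibition and higher numbers for weaker inhibition), and read as follows
- compound 1 `S=C(NCc1ccccc1)N/N=C/c1ccc2ccccc2n1` gives 21900 nM
- compound 2 `NC(=S)N/N=C/c1ccc2ccccc2n1` gives > 100000 nM (a limit of the assay)
- compound 3 `Cc1ccc(NC(=S)N/N=C/c2ccc3ccccc3n2)cc1` gives 78300 nM

Of the two values that are true numbers, compound 3 holds the higher, with a 3.6-fold higher number from compound 1 to compound 3 (0.55 log units; beyond the scatter) in the series. Compound 4 `S=C(N/N=C/c1ccc2ccccc2n1)Nc1ccc(Cl)cc1` differs from compound 3 by chloro in place of methyl on an aromatic carbon with chloro in place of methyl on an aromatic carbon, para to a large group. Among the compounds with values here, no measured step makes this exchange. The nearest evidence changes the group on the amide-type nitrogen instead: an at least 4.5-fold higher number from compound 1 to compound 2 (0.65 log units; beyond the scatter) and an at least 1.2-fold lower number from compound 2 to compound 3 (0.10 log units; that floor lies within the scatter), along with the step from compound 1 to compound 3 given above. These steps are modest at most, and they leave compound 3 with 78300 nM not far under the limit of > 100000 nM in this assay, at which 1 of the 3 values shown sits, in the series. A small change in this assay is therefore expected, probably toward a lower number and probably not beyond the scatter. The expected step is a 1.6-fold lower number from compound 3 to compound 4 (0.19 log units; within the scatter) in this series. The estimate for compound 4 is 50000 nM with an expected range from 15000 nM to 100000 nM in this assay.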

Compound 4, half-maximal inhibitory concentration: > 100000 nM
Compound 4: no number, only a limit; the forecaster's own chance of this, stated with the estimate: 20%; middle value at least 2.0-fold (0.30 log units) from the limit.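

Compound 4 stands at a limit of the assay, so chloro in place of methyl on an aromatic carbon, para to a large group, gives only an at least 1.2-fold higher number from compound 3 to compound 4 (0.10 log units; that floor lies within the scatter), and the real size of the exchange cannot be read. Against benzyl, the 4-chlorophenyl group on the amide-type nitrogen gives an at least 4.5-fold higher number from compound 1 to compound 4 (0.65 log units; beyond the scatter), which leaves compound 1 with the lowest number of the series. The step from compound 2 to compound 4 cannot be read, and limits now take a larger share of the series: the limit of > 100000 nM in this assay, at which 2 of the 4 values shown sit.

Open, going by these compounds, is whether methoxy or an amine at this place would read as a true number in this assay. Also open, on these data alone, is how chloro on the benzyl group of compound 1, at 21900 nM, would read.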